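Exchanging the group on the sulfonyl sulfur

The source may report more compounds than this note shows. Statements on the series, on what has been measured and on what is new or still open speak of the compounds shown alone.

In a functional assay on HEK293 cells (Homo sapiens) for cytotoxicity (on this read-out higher numbers stand for lower toxicity in this test and lower numbers for higher toxicity in this test), compound 3 `COc1ccc([C@H]2CC(=O)N(c3cccc(NS(=O)(=O)c4cccc(Br)c4)c3)C2)cc1OC1CCCC1` gives > 10000 nM, which is a limit and not a number. Compound 1 `CCCCNc1cccc(N2C[C@@H](c3ccc(OC)c(OC4CCCC4)c3)CC2=O)c1` gives > 10000 nM, also a limit. Compound 2 `COc1ccc([C@H]2CC(=O)N(c3cccc(NC(=O)C(C)=O)c3)C2)cc1OC1CCCC1` gives > 10000 nM, again a limit. All measured values therefore coincide: the limit of > 10000 nM in this assay, at which 3 of the 3 values shown sit.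

Compound 4 `COc1ccc([C@H]2CC(=O)N(c3cccc(NS(=O)(=O)c4c(Br)nn(C)c4Cl)c3)C2)cc1OC1CCCC1` differs from compound 3 as follows: 3-bromo-5-chloro-1-methyl-1H-pyrazol-4-yl in place of 3-bromophenyl on a sulfonyl sulfur.

The measured changes bearing on this are a step that the two limits leave unreadable from compound 1 to compound 3 and a step that the two limits leave unreadable from compound 2 to compound 3. Neither has a readable size, so the expectation for this exchange remains weakly grounded. The estimated step that the limit leaves unreadable from compound 3 to compound 4 is expected to stay within the scatter, with no direction favoured. The expected value for compound 4 is 15000 nM, within an estimated range of 6000 nM to 40000 nM.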

Compound 4, half-maximal cytotoxic concentration: > 10000 nM
Compound 4 was reported as a limit (the forecaster's own chance of this, stated with the estimate: 85%); the middle value is on the limit's open side.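

For the compounds shown here, compound 4 gives a limit in this assay, as do compounds 1, 2 and 3, so no step among them can be read: the limit of > 10000 nM in this assay, at which 4 of the 4 values shown sit. The compounds shown leave open whether any of these exchanges changes the read-out at all.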